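Benzyl in Place of Cyclohexyl on a Shared Core

This account rests on a few compounds, and the source may have more. Where it says the series, first, only, none or still open, it means among the compounds named here.

Three compounds have been measured in a functional assay on IGROV-1 cells (Homo sapiens) for inhibition, read by sulforhodamine B assay, with a stated time of 48 h, tested at 10 uM; on this read-out higher numbers stand for more inhibition at the one concentration tested (going by the name of the read-out) and lower numbers for less inhibition:

Compound 1, `O=Cc1ccc(-c2cn3ccnc3c(-c3ccc4ncn(C5CCCCC5)c4c3)n2)cc1`, gives 21.3%.
Compound 2, `O=Cc1ccc(-c2cn3ccnc3c(-c3ccc4ncn(Cc5ccccc5)c4c3)n2)cc1`, gives 21.3%.
Compound 3, `c1cn2cc(-c3ccc4c(c3)ncn4C3CCCCC3)nc(-c3ccc4ncn(C5CCCCC5)c4c3)c2n1`, gives 8.51%.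

Compound 4, `c1ccc(Cn2cnc3ccc(-c4nc(-c5ccc6c(c5)ncn6C5CCCCC5)cn5ccnc45)cc32)cc1`, remains to be measured in this assay.

The change from compound 1 to compound 2 is benzyl in place of cyclohexyl on an aromatic nitrogen, and in this assay it gave no change at the digits printed from compound 1 to compound 2 (within the scatter). The change from compound 3 to compound 4 is benzyl in place of cyclohexyl on an aromatic nitrogen, the same change at the same kind of place. The difference between the core of compound 1 and the core of compound 3 is not broken down here; what the numbers show is that compound 3 stands at the lowest of the three values, beyond the scatter from both compound 1 and compound 2.

For compound 4 a step of a number 0.5 percentage points higher from compound 3 to compound 4 (within the scatter) in this assay is expected, resting on the fact that the same change from compound 1 to compound 2 produced no change at the digits printed from compound 1 to compound 2 (within the scatter). Compound 4 is therefore estimated at 9%, with a likely range from 0% to 20%.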

Compound 4, a percentage reported as inhibition, at one concentration (the size of the read-out at that concentration, not a potency): 94.2%
Beside the measured number, compound 4's estimate is 85.2 percentage points below it; measured number outside the range, above it.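

In this assay, benzyl in place of cyclohexyl on an aromatic nitrogen gave a number 85.7 percentage points higher from compound 3 to compound 4 (beyond the scatter), so on this second core the change had a large effect. Set beside the earlier pair, the same change did not carry over from one core to the other with the same result: the same change on two cores in this assay, no change at the digits printed (within the scatter) from compound 1 to compound 2 and a number 85.7 percentage points higher (beyond the scatter) from compound 3 to compound 4, 85.7 percentage points apart, beyond the scatter of two such steps This shows that, for these two pairs, the outcome of the change cannot be read from one core to the other, but it does not show which feature of the cores accounts for the gap, and as a reading at one concentration it gives no potency for compound 4.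

The compounds shown leave open whether a longer chain such as phenylethyl, or an amine-bearing chain, on the same aromatic nitrogen would give a result like that of benzyl in compound 4. They also leave open how either group would behave on any core beyond these two.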